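Closing a chain into a ring: from compound 2 to compound 4

This account rests on a few compounds, and the source may have more. Where it says the series, first, only, none or still open, it means among the compounds named here.

Three measured compounds share one core. Compound 1 `CCNC(=O)[C@H]1O[C@@H](n2cnc3c(NC)nc(-n4cc(Cc5ccccc5)nn4)nc32)[C@H](O)[C@@H]1O` gives 2.8 nM in an assay on CHO cells for displacement of a labelled ligand from adenosine receptor A3 (Homo sapiens); a lower number here means a stronger inhibitor, a higher number a weaker inhibitor. Compound 2 `CCCCc1cn(-c2nc(NC)c3ncn([C@@H]4O[C@H](C(=O)NCC)[C@@H](O)[C@H]4O)c3n2)nn1` gives 5.6 nM in this assay, and a 2.0-fold higher number from compound 1 to compound 2 (0.30 log units; within the scatter). Compound 3 `CCCCc1cn(-c2nc(NC)c3ncn([C@@H]4O[C@H](CO)[C@@H](O)[C@H]4O)c3n2)nn1` gives 11.7 nM in this assay, and a 2.1-fold higher number from compound 2 to compound 3 (0.32 log units; beyond the scatter). Among these three numbers compound 2 stands in the middle: it lies within the scatter of compound 1, while compound 3 sits a modest step higher.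

Compound 4 `CCNC(=O)[C@H]1O[C@@H](n2cnc3c(NC)nc(-n4cc(CC5CCCC5)nn4)nc32)[C@H](O)[C@@H]1O` is not yet measured. It differs from compound 2 in one place: cyclopentyl in place of propyl on a saturated chain carbon bound to an aromatic carbon. The measured step that bears most directly on this change is a 2.0-fold higher number from compound 1 to compound 2 (0.30 log units; within the scatter), where an exchange at the same saturated chain carbon moved the number only within the scatter. The other step, a 2.1-fold higher number from compound 2 to compound 3 (0.32 log units; beyond the scatter), touches a different part of the molecule and shows only how narrow the spread of numbers is here. Given that a 2.0-fold higher number from compound 1 to compound 2 (0.30 log units; within the scatter) stayed within the scatter, the change to compound 4 is expected to be a 1.2-fold lower number from compound 2 to compound 4 (0.09 log units; within the scatter), not beyond the scatter. Compound 4 is therefore estimated at 4.5 nM in this assay, with a range from 1.5 nM to 14 nM.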

Compound 4, inhibition constant: 11.5 nM
Compound 4: middle estimate off by 2.6-fold (0.41 log units), on the low side; low and high end bracket the measured number.
By their numbers in this assay, from the lowest: compounds 1 and 2 (each within the scatter of the next); then compounds 4 and 3 (each within the scatter of the next).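

In this assay the exchange of phenyl for propyl had stayed within the scatter, which left it unclear whether the group on this saturated chain carbon bound to an aromatic carbon mattered at all; the new steps show that it does, with a 2.1-fold higher number from compound 2 to compound 4 (0.31 log units; beyond the scatter) for cyclopentyl in place of propyl. Cyclopentyl also separates from phenyl, with a 4.1-fold higher number from compound 1 to compound 4 (0.61 log units; beyond the scatter), so carrying a ring at this place does not by itself set the number: compound 1 and compound 4 both have one, and only the ring in compound 4 is the five-membered non-aromatic one of carbon only. Both steps are modest, so among these compounds the position responds to the change without any large move, and nothing shown gives a reason for that response.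

The compounds shown cannot separate the closing of the ring from the added carbons, since an open pentyl chain and a smaller or larger ring such as cyclobutyl or cyclohexyl do not appear among them. Going by these compounds, it also remains open whether cyclopentyl would give a similar step with hydroxymethyl in place of ethylcarbamoyl on the saturated ring carbon.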